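Replacing the 3-cyanophenyl group of compound 2

The source may hold more compounds than are shown below. What is called first, only, known or untested is meant among the compounds shown, and "the series" means these compounds.

In a functional assay on MCF7 cells (Homo sapiens) for antiproliferative activity, read by MTT assay, with a stated time of 72 h (a lower number here means a stronger inhibitor, a higher number a weaker inhibitor), compound 1 `C=CC(=O)Nc1cccc(Oc2nc(Nc3cccc(C#N)c3)nc3c2CSCC3)c1` gives 21700 nM and compound 2 `C/C=C/C(=O)Nc1cccc(Oc2nc(Nc3cccc(C#N)c3)nc3c2CSCC3)c1` gives 21400 nM, two values within the scatter of each other. Compound 3 `CC(C)=CC(=O)Nc1cccc(Oc2nc(Nc3cccc(C#N)c3)nc3c2CSCC3)c1` gives > 50000 nM, which is a limit of the assay and not a number. Among the measured compounds shown here, compound 2 thus stands level with compound 1, and these are the only two numbers in the set.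

Compound 4 `C/C=C/C(=O)Nc1cccc(Oc2nc(Nc3ccc(OC)nc3)nc3c2CSCC3)c1` differs from compound 2 in one group: 6-methoxypyridin-3-yl in place of 3-cyanophenyl on a nitrogen on an aromatic ring. In words, 6-methoxypyridin-3-yl stands in place of 3-cyanophenyl on a nitrogen on an aromatic ring.

The measured steps all concern the group on the carbonyl carbon: a 1.0-fold lower number from compound 1 to compound 2 (0.01 log units; within the scatter), an at least 2.3-fold higher number from compound 1 to compound 3 (0.36 log units; beyond the scatter) and an at least 2.3-fold higher number from compound 2 to compound 3 (0.36 log units; beyond the scatter). None of them touches the 3-cyanophenyl group, so they give neither a size nor a direction for this exchange. They bear on it only indirectly, by showing where values in this set lie. In this assay the expected step, a 1.0-fold lower number from compound 2 to compound 4 (0.01 log units; within the scatter), is therefore none beyond the scatter, and the range is kept wide on both sides. Compound 4 is estimated at 21000 nM. Its value is expected to fall between 7000 nM and 50000 nM.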

Compound 4, half-maximal inhibitory concentration: 21100 nM
Estimate against measurement, compound 4: 1.0-fold (0.00 log units) below; measured number inside the range.
By their numbers in this assay, from the lowest: compounds 4, 2 and 1 (each within the scatter of the next). At a limit, above all of these: compound 3.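

In this assay, among the compounds shown here, 6-methoxypyridin-3-yl in place of 3-cyanophenyl on a nitrogen on an aromatic ring gives a 1.0-fold lower number from compound 2 to compound 4 (0.01 log units; within the scatter), the first measured step at this position, since all earlier steps concerned the group on the carbonyl carbon. In this pair, the group that leaves holds a nitrile on a ring of carbon only, and the group that enters holds a methoxy on a ring with a hetero atom, yet the two numbers stay within the scatter of each other, so neither the nitrile nor the all-carbon ring is needed to keep the value of compound 2 in this assay. This step joins two numbers, and the only compound at a limit of the assay, which is not a number, is compound 3: the limit of > 50000 nM in this assay, at which 1 of the 4 values shown sits.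

On these data alone, whether other groups on this nitrogen, such as a phenyl ring carrying a carboxylic acid, a morpholine ring or a plain alkyl chain, would also leave the number in place stays open, and a single step sets no trend. Also open, as far as these compounds go, is whether the same exchange would read the same with vinyl or 2-methylprop-1-en-1-yl on the carbonyl carbon in place of prop-1-en-1-yl.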